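A few compounds are considered here, and "the series" means these few. Any claim that something is new, unique, unknown or untested is made for them only; others in the source may bear on it.

In an ADME assay on BJ cells (Homo sapiens) for cytotoxicity, with a stated time of 72 h (a lower number here means that less compound is needed, a higher number that more compound is needed for the effect), compound 2 (`COc1ccc(-c2nc3c(c(C)nn3-c3ccccc3)c(-c3ccccc3O)c2C#N)cc1`) is known only by a limit, > 23000 nM. Compound 1 (`CCc1ccc(-c2nc3c(c(C)nn3-c3ccccc3)c(-c3ccccc3O)c2C#N)cc1`) is likewise known only by a limit, > 20000 nM. Neither compound has given a number, so the position of compound 2 on this scale is open on its upper side.

Compound 3 (`COc1cccc(-c2nc3c(c(C)nn3-c3ccccc3)c(-c3ccccc3O)c2C#N)c1`) carries 3-methoxyphenyl in place of 4-methoxyphenyl on an aromatic carbon next to the ring nitrogen and ortho to a cyano group: 3-methoxyphenyl in place of 4-methoxyphenyl on an aromatic carbon. The same atoms are simply joined differently. Going by the values given here, the only measured step nearby is a step that the two limits leave unreadable from compound 1 to compound 2, a change of methoxy in place of ethyl at this same carbon's aryl group, and it offers no size to carry over.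

No shift beyond the scatter is therefore expected, and the expected step is a step that the limit leaves unreadable from compound 2 to compound 3. For compound 3 the estimated value is 25000 nM, with an expected range from 12000 nM to 50000 nM, and a further limit is the likeliest report.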

Compound 3, half-maximal effective concentration: > 23000 nM
Compound 3: a limit, no number; the forecaster's own chance of this, stated with the estimate: 75%; the middle value is on the limit's open side.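

In this assay compound 3 gives > 23000 nM, a limit and not a number. Compound 1, compound 2 and compound 3 are all known only by limits, and the steps among them cannot be read. The compounds shown leave open at what concentration any of them reaches the effect, and whether 3-methoxyphenyl and 4-methoxyphenyl differ at all.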